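Swapping the anilino aryl group of compound 2

The compounds below may be only part of what the source reports. "The series", "measured", "known", "first", "only" and "open" are said of these compounds alone.

Of the compounds shown here, three have been measured in a functional assay on NCI-H460 cells (Homo sapiens) for antiproliferative activity, read by CCK-8 assay, with a stated time of 72 h, tested at 8 uM; a higher number here means a stronger effect of the compound at the concentration tested, a lower number a weaker effect. Compound 1 `CCCCn1cnc2c(Nc3cccc(Cl)c3)nc(NCOCc3ccc(/C=C/C(=O)Nc4ccccc4N)cc3)nc21` gives 51.1%, compound 3 `CC(C)n1cnc2c(Nc3cccc(Cl)c3)nc(NCOCc3ccc(/C=C/C(=O)Nc4ccccc4N)cc3)nc21` gives 61.1%, and compound 2 `Cc1ccc(Nc2nc(Cl)nc3c2ncn3Cc2ccc(C(=O)Nc3ccccc3N)cc2)cc1` gives 82.5%. Compound 2 thus stands highest of the three: its nearest neighbour is compound 3, a number beyond the scatter lower, and compound 1 lies furthest, also beyond the scatter. For the measured compounds named here, the only step between two measured compounds that differ in one place is a number 10 percentage points higher from compound 1 to compound 3 (within the scatter), a change that touches the alkyl group on an aromatic nitrogen, not the aryl group on the anilino nitrogen.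

Compound 4 `Nc1ccccc1NC(=O)c1ccc(Cn2cnc3c(Nc4cccc(OC(F)(F)F)c4)nc(Cl)nc32)cc1` differs from compound 2 by 3-(trifluoromethoxy)phenyl in place of 4-methylphenyl on a nitrogen on an aromatic ring. Going by the values given here, no measured step changes this aryl group on a single place, so there is no direct precedent for its size or direction. Compound 1 and compound 3, which carry a different aryl group there, give lower numbers than compound 2, but they differ from compound 2 in several places at once, so their values cannot be read as a step of this kind. The expected change in this assay for compound 4 is therefore a number 9.5 percentage points lower from compound 2 to compound 4 (within the scatter), a modest move that may still fall within the scatter. Compound 4 is estimated at 73%, within a range from 52% to 90%.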

Compound 4, a percentage reported as inhibition, at one concentration (the size of the read-out at that concentration, not a potency): 62.4%
Beside the measured number, compound 4's estimate is 10.6 percentage points above it, within the range that was stated.
By their numbers in this assay, from the lowest: compounds 1, 3 and 4 (each within the scatter of the next, the first and the last beyond it); then compound 2.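

In this assay, for the compounds shown here, the step of a number 20.1 percentage points lower from compound 2 to compound 4 (beyond the scatter) is the first single change on the aryl group of the anilino nitrogen, and it lies beyond the scatter, so the read-out at this concentration does respond to what sits at this position. Going by these compounds alone, the only earlier step, a number 10 percentage points higher from compound 1 to compound 3 (within the scatter), concerned the alkyl group on an aromatic nitrogen and stayed within the scatter, so it said nothing about this aryl group. The new step replaces 4-methylphenyl with the larger 3-(trifluoromethoxy)phenyl, but nothing measured here explains why the number falls.

This one step changes both the substituent and where it sits on the ring, so it cannot show which of the two matters, and a plain phenyl group or a methoxy group on that ring would help to separate them. From the compounds shown here alone, it also remains open how far this fall carries over to compounds with other groups elsewhere on the core, such as an amine in place of the chlorine, and whether it would hold at concentrations other than the single one tested.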